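Benzyl for cyclohexyl on an aromatic nitrogen: inhibition notes

The compounds below may be only part of what the source reports. "The series", "measured", "known", "first", "only" and "open" are said of these compounds alone.

Measured so far in a functional assay on NCI-H460 cells (Homo sapiens) for inhibition, read by sulforhodamine B assay, with a stated time of 48 h, tested at 10 uM; on this read-out lower numbers stand for less inhibition and higher numbers for more inhibition at the one concentration tested (going by the name of the read-out):
- compound 1 `O=Cc1ccc(-c2cn3ccnc3c(-c3ccc4ncn(C5CCCCC5)c4c3)n2)cc1`: 37.8%
- compound 2 `O=Cc1ccc(-c2cn3ccnc3c(-c3ccc4ncn(Cc5ccccc5)c4c3)n2)cc1`: 37.8%
- compound 3 `c1cn2cc(-c3ccc4c(c3)ncn4C3CCCCC3)nc(-c3ccc4ncn(C5CCCCC5)c4c3)c2n1`: 11.9%

Compound 1 and compound 2 differ only by benzyl in place of cyclohexyl on an aromatic nitrogen; the step of no change at the digits printed from compound 1 to compound 2 (within the scatter). Compound 3 carries a different core; the difference between the cores of compound 1 and compound 3 is not broken down here. In this assay compound 3 gives the least inhibition of the three, beyond the scatter from both others.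

Compound 4 `c1ccc(Cn2cnc3ccc(-c4nc(-c5ccc6c(c5)ncn6C5CCCCC5)cn5ccnc45)cc32)cc1` is not yet measured. It differs from compound 3 by benzyl in place of cyclohexyl on an aromatic nitrogen, the same change as from compound 1 to compound 2, at the same kind of place. Because no change at the digits printed from compound 1 to compound 2 (within the scatter), the step of a number 1.1 percentage points higher from compound 3 to compound 4 (within the scatter) is expected to be small as well. For compound 4 the estimate in this assay is 13%, expected between -2% and 32%.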

Compound 4, a percentage reported as inhibition, at one concentration (the size of the read-out at that concentration, not a potency): -20.3%
Compound 4: middle estimate off by 33.3 percentage points, on the high side, outside the stated range (below it).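

On the core of compound 3, benzyl in place of cyclohexyl on an aromatic nitrogen gives a number 32.2 percentage points lower from compound 3 to compound 4 (beyond the scatter), whereas on the core of compound 1 the same change gives no change at the digits printed from compound 1 to compound 2 (within the scatter). In this assay, this change therefore does not carry over from one core to the other with the same effect: the same change on two cores in this assay, no change at the digits printed (within the scatter) from compound 1 to compound 2 and a number 32.2 percentage points lower (beyond the scatter) from compound 3 to compound 4, 32.2 percentage points apart, beyond the scatter of two such steps. This comparison rests on a single pair for each of two cores at one concentration, so it shows that the outcome depends on the core but does not show which feature of the core is responsible or how the change would behave on a third core.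

The compounds shown leave open how other groups on that aromatic nitrogen, such as methyl or a longer chain ending in an amine, would behave on either core. From the compounds shown here alone, it also remains open whether a carboxylic acid in place of the aldehyde on the core of compound 1 would alter the step.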